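The source may hold more compounds than are shown below. What is called first, only, known or untested is meant among the compounds shown, and "the series" means these compounds.

Measured compounds:
compound 1 `CCCN(CC[C@H]1CC[C@H](NC(=O)c2ccccc2-n2cccn2)CC1)[C@H]1CCc2nc(N)sc2C1`: 2 nM
compound 2 `CCCN(CC[C@H]1CC[C@H](NC(=O)c2cccc(-n3cncn3)c2)CC1)[C@H]1CCc2nc(N)sc2C1`: 3 nM

In an assay on brain for displacement of a labelled ligand from D(3) dopamine receptor (Rattus norvegicus) (on this read-out lower numbers stand for stronger inhibition and higher numbers for weaker inhibition), compound 1 gives 2 nM, and in the same assay compound 2 gives 3 nM. For the measured compounds named here, compound 2 carries the higher of the two numbers, but its only neighbour is close: a 1.5-fold higher number from compound 1 to compound 2 (0.18 log units; within the scatter), so the two stand level.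

Compound 3 `CCCN(CC[C@H]1CC[C@H](NC(=O)c2cccc(-n3ccnc3)c2)CC1)[C@H]1CCc2nc(N)sc2C1` is not yet measured. It differs from compound 2 in one place: 1H-imidazol-1-yl in place of 1H-1,2,4-triazol-1-yl on an aromatic carbon. Going by the values given here, the one measured step that touches this region, a 1.5-fold higher number from compound 1 to compound 2 (0.18 log units; within the scatter), exchanged one five-membered aromatic ring for another and stayed within the scatter, though it also moved the ring to a different carbon, so it bears on the present change only loosely. Among the compounds with values here, no step swaps one ring for another at the same carbon. The expected step is therefore small, no change at the digits printed from compound 2 to compound 3 (within the scatter), with no direction beyond the scatter. Compound 3 is estimated at 3 nM, with a range from 1 nM to 9 nM.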

Compound 3, inhibition constant: 1.1 nM
For compound 3 the middle estimate is 2.7-fold (0.44 log units) above the measured one, and the stated range covers the measured number.
By their numbers in this assay, from the lowest: compounds 3, 1 and 2 (each within the scatter of the next, the first and the last beyond it).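

In this assay, for the compounds shown here, 1H-imidazol-1-yl in place of 1H-1,2,4-triazol-1-yl on the same aromatic carbon gives a 2.7-fold lower number from compound 2 to compound 3 (0.44 log units; beyond the scatter), the only step in this set beyond the scatter, so the number at this position depends, modestly, on which five-membered aromatic ring is present. The comparison with the other ring and attachment gives a 1.8-fold lower number from compound 1 to compound 3 (0.26 log units; within the scatter), which leaves compound 3 level with compound 1, and the gain over the triazole does not separate 3-(1H-imidazol-1-yl)phenyl from 2-(1H-pyrazol-1-yl)phenyl. No supporting measurement bears on why the two rings differ.

Open, on these data alone, is whether a group other than a five-membered aromatic ring, such as an amine or a carboxylic acid, would be tolerated on this carbon. Also open, as far as these compounds go, is whether the difference between the two rings would persist with changes elsewhere in the shared core.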